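The compounds below may be only part of what the source reports. "The series", "measured", "known", "first", "only" and "open" are said of these compounds alone.

Measured so far:
Compound 1 `CC(=O)N1N=C(c2ccc(OCc3cn(Cc4ccc([N+](=O)[O-])cc4)nn3)cc2)CC1c1ccccc1`: 18%
Compound 2 `COc1cc(C2CC(c3ccc([N+](=O)[O-])cc3)=NN2C(C)=O)ccc1OCc1cn(Cc2ccc([N+](=O)[O-])cc2)nn1`: 33%
Compound 3 `COc1cc(C2CC(c3ccccc3)=NN2C(C)=O)ccc1OCc1cn(Cc2ccc([N+](=O)[O-])cc2)nn1`: 7%

In a functional assay on COLO 205 cells (Homo sapiens) for inhibition, read by sulforhodamine B assay, tested at 10 uM (on this read-out lower numbers stand for less inhibition of growth and higher numbers for more inhibition of growth at the one concentration tested), compound 2 gives the highest of the three numbers, with compound 1 and compound 3 both beyond the scatter below it. Compound 4 `COc1ccc(C2=NN(C(C)=O)C(c3ccc(OCc4cn(Cc5ccc([N+](=O)[O-])cc5)nn4)c(OC)c3)C2)cc1` differs from compound 2 by methoxy in place of nitro on an aromatic carbon. Within the data shown here, one measured step bears on this: removing the same nitro gave a number 26 percentage points lower from compound 2 to compound 3 (beyond the scatter). Compound 4 also loses that nitro, so a drop is expected, though the incoming methoxy leaves its exact size uncertain. Compound 4 is expected to give about 15%, within 2% to 32%. Among the measured compounds shown here, the estimated change is a number 18 percentage points lower from compound 2 to compound 4 (beyond the scatter), because a number 26 percentage points lower from compound 2 to compound 3 (beyond the scatter) is the only guide for losing this nitro.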

Compound 4, percent growth inhibition at one concentration: 10%
The estimate for compound 4 lay 5 percentage points above the measured number; low and high end bracket the measured number.
By their numbers in this assay, from the lowest: compounds 3, 4 and 1 (each within the scatter of the next, the first and the last beyond it); then compound 2.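

In this assay, going from 4-nitrophenyl to 4-methoxyphenyl gives a number 23 percentage points lower from compound 2 to compound 4 (beyond the scatter), so the higher number is lost with a second replacement as well as with plain hydrogen. Methoxy in place of hydrogen at this position gives a number 3 percentage points higher from compound 3 to compound 4 (within the scatter), so these two groups cannot be told apart here, and of the three groups only nitro stands out. Nothing measured here gives a reason for this.

On these data alone, whether an amine or a carboxylic acid on this aromatic carbon would keep the number of compound 2 remains open. Also open, as far as these compounds go, is whether a nitrile would do so.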